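Three configurational variants of one structure in melanoma cells

The source may hold more compounds than are shown below. What is called first, only, known or untested is meant among the compounds shown, and "the series" means these compounds.

compound 1 `O=C(/C=C\c1ccc(O)cc1)O[C@H]1[C@H](O[C@@H]2CCCC[C@H]2O)O[C@H](CO)[C@@H](O)[C@@H]1O`: > 10000 nM
compound 2 `O=C(/C=C\c1ccc(O)cc1)O[C@@H]1[C@H](O[C@@H]2CCCC[C@@H]2O)O[C@H](CO)[C@@H](O)[C@H]1O`: > 10000 nM

Of the compounds shown here, two have been measured in a functional assay on SK-MEL-2 cells (Homo sapiens) for cytotoxicity, read by sulforhodamine B assay; a higher number here means a weaker inhibitor, a lower number a stronger inhibitor. Compound 1 gives only a limit of the assay, > 10000 nM. Compound 2 likewise gives only a limit, > 10000 nM. The step that the two limits leave unreadable from compound 1 to compound 2 therefore cannot be sized; what can be said rests on the limit of > 10000 nM in this assay, at which 2 of the 2 values shown sit, and on (the fact that compounds 1 and 2 differ only in the configuration as drawn). Within the data shown here, compound 2 thus stands at the limit, alongside the one other value shown.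

Compound 3 `O=C(/C=C/c1ccc(O)cc1)O[C@H]1[C@H](O[C@H]2CCCC[C@H]2O)O[C@H](CO)[C@@H](O)[C@@H]1O` has not been measured. Its relation to compound 2 is the two compounds have the same atoms and bonds and differ only in configuration as drawn: 5 of 8 stereo elements differ; a stereocentre at a saturated ring carbon is drawn S in compound 2 and R in compound 3; a stereocentre at a saturated ring carbon is drawn R in compound 2 and S in compound 3; a stereocentre at a saturated ring carbon is drawn S in compound 2 and R in compound 3; a stereocentre at a saturated ring carbon is drawn R in compound 2 and S in compound 3. Among the measured compounds shown here, the only measured step, from compound 1 to compound 2, is itself a change of configuration alone and is unreadable in size, so it offers no direction for the step to compound 3. The step of a number no higher from compound 2 to compound 3 (the limit leaves the size open) is therefore expected to be none beyond the scatter, with a wide range because both values shown are limits. Compound 3 is estimated at 10000 nM, between 2500 nM and 40000 nM, most likely again reported only as a limit.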

Compound 3, half-maximal inhibitory concentration: > 10000 nM
Compound 3 gave a limit, no number; the forecaster's own chance of this, stated with the estimate: 70%; the middle value sits exactly at the limit.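

In this assay, among these compounds, compound 3 gives > 10000 nM, a limit of the assay and not a number, so no step among compound 1, compound 2 and compound 3 can be read. Whether these differences in configuration change the cytotoxicity at all stays open, as all three compounds rest on the same limit: the limit of > 10000 nM in this assay, at which 3 of the 3 values shown sit.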